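Three Chlorines on the Phenyl of a Weak Series

The source may hold more compounds than are shown below. What is called first, only, known or untested is meant among the compounds shown, and "the series" means these compounds.

Compound 3, `Cc1ccc(-n2nncc2CN2C(=O)C3(C(C#N)=C(N)Oc4c(N)cc5nc6ccccc6nc5c43)c3ccccc32)cc1Cl`, is tested in a functional assay on MCF7 cells (Homo sapiens) for antiproliferative activity, read by MTT assay, with a stated time of 48 h (a higher number here means a weaker inhibitor, a lower number a stronger inhibitor), where compound 3 gives > 50000 nM, a limit of the assay rather than a number. Compound 1, `Cc1cccc(-n2nncc2CN2C(=O)C3(C(C#N)=C(N)Oc4c(N)cc5nc6ccccc6nc5c43)c3ccccc32)c1`, gives > 50000 nM, likewise a limit. Compound 2, `N#CC1=C(N)Oc2c(N)cc3nc4ccccc4nc3c2C12C(=O)N(Cc1cnnn1-c1cc(Cl)ccc1Cl)c1ccccc12`, gives 33200 nM. The shared core carries a phenyl on an aromatic nitrogen, and the limit of > 50000 nM in this assay, at which 2 of the 3 values shown sit, marks the ceiling of this series. The steps read an at least 1.5-fold lower number from compound 1 to compound 2 (0.17 log units; that floor lies within the scatter), an at least 1.5-fold higher number from compound 2 to compound 3 (0.17 log units; that floor lies within the scatter) and a step that the two limits leave unreadable from compound 1 to compound 3. Compound 4, `N#CC1=C(N)Oc2c(N)cc3nc4ccccc4nc3c2C12C(=O)N(Cc1cnnn1-c1c(Cl)cc(Cl)cc1Cl)c1ccccc12`, brings (2,4,6-trichlorophenyl in place of 3-chloro-4-methylphenyl on an aromatic nitrogen). Two chlorines on this phenyl in compound 2 gave a readable number, so compound 4 is expected to sit near the ceiling, with an at least 1.2-fold lower number from compound 3 to compound 4 (0.09 log units; that floor lies within the scatter) as the expected step. The estimate for compound 4 is 40000 nM, between 20000 nM and 60000 nM.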

Compound 4, half-maximal inhibitory concentration: 37800 nM
Compound 4: the middle estimate sits 1.1-fold (0.02 log units) above what was measured; low and high end bracket the measured number.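

Compound 4 is the second compound with a readable number, so a phenyl carrying three chlorines behaves like the one carrying two, with a 1.1-fold higher number from compound 2 to compound 4 (0.06 log units; within the scatter). Against the two phenyls that carry a methyl, the steps are an at least 1.3-fold lower number from compound 3 to compound 4 (0.12 log units; that floor lies within the scatter) and an at least 1.3-fold lower number from compound 1 to compound 4 (0.12 log units; that floor lies within the scatter), so among these four compounds only the phenyls bearing chlorine alone give a number, yet no step is shown to exceed the scatter. All of this lies close to the ceiling: the limit of > 50000 nM in this assay, at which 2 of the 4 values shown sit.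

As far as these compounds go, whether a phenyl bearing an amine or a carboxylic acid on this aromatic nitrogen would move the number clearly away from that ceiling stays open.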